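Methyl step from compound 3 to compound 4

The compounds below may be only part of what the source reports. "The series", "measured", "known", "first", "only" and "open" are said of these compounds alone.

In an ADME assay on MT4 cells (Homo sapiens) for cytotoxicity, read by MTT assay, with a stated time of 4 days (a higher number here means that more compound is tolerated, a lower number that less compound is tolerated), compound 3 `CC(c1cc(=O)[nH]c(N(C)C)n1)c1c(F)cccc1F` gives 89000 nM, the highest of the numbers in hand. Compound 1 `CCCNc1nc(C(C)c2c(F)cccc2F)c(C)c(=O)[nH]1` gives 35000 nM, and its gap to compound 3 lies beyond the scatter. Compound 2 `Cc1c(Cc2c(F)cccc2F)nc(N(C)C)[nH]c1=O` reads > 89000 nM, which is a limit and not a number.

The next structure is compound 4 `Cc1c(C(C)c2c(F)cccc2F)nc(N(C)C)[nH]c1=O`, with methyl in place of hydrogen on an aromatic carbon. For the measured compounds named here, no measured pair isolates this change. Compound 1 and compound 2 both carry a methyl on that aromatic carbon, but each also differs from compound 3 elsewhere, so they offer only indirect guidance. In this assay a small move towards a lower number is expected, probably not beyond the scatter. The estimated change is a 1.3-fold lower number from compound 3 to compound 4 (0.10 log units; within the scatter). Compound 4 is estimated at 70000 nM, with an expected range from 28000 nM to 120000 nM.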

Compound 4, half-maximal cytotoxic concentration: > 17000 nM
Compound 4: a limit, no number; the forecaster's own chance of this, stated with the estimate: 40%; the middle value does not contradict the limit.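

In this assay compound 4 gives > 17000 nM as a limit and not a number. For the compounds shown here, no step to compound 4 from compound 1, compound 2 or compound 3 can be read. The compounds shown leave open what methyl in place of hydrogen on an aromatic carbon does to the tolerated concentration.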